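The source may report more compounds than this note shows. Statements on the series, on what has been measured and on what is new or still open speak of the compounds shown alone.

Compound 1, `CN(C)C(=O)c1cc2cnc(Nc3ccc(NC(=O)C4(C(=O)Nc5cccc(C(F)(F)F)c5)CC4)cc3)nc2n1C1CCCC1`, gives 89.2% in a functional assay on A549 cells (Homo sapiens) for inhibition, read by CCK-8 assay, with a stated time of 72 h, tested at 10 uM; a higher number here means more inhibition of growth at the concentration tested, a lower number less inhibition of growth. Compound 2, `COC(=O)c1ccc(NC(=O)C2(C(=O)Nc3ccc(Nc4ncc5cc(C(=O)N(C)C)n(C6CCCC6)c5n4)cc3)CC2)cc1`, gives 92% in this assay. Compound 3, `CN(C)C(=O)c1cc2cnc(Nc3ccc(NC(=O)C4(C(=O)Nc5cccc(F)c5)CC4)cc3)nc2n1C1CCCC1`, gives 91.8% in this assay.

Compound 3 stands second highest of the three numbers. Its nearest neighbour is compound 2, the step being a number 0.2 percentage points lower from compound 2 to compound 3 (within the scatter); the furthest is compound 1, with a number 2.6 percentage points higher from compound 1 to compound 3 (within the scatter). All three compounds share the same core, and they differ only in the aryl group carried on the amide-type nitrogen.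

Compound 4, `CN(C)C(=O)c1cc2cnc(Nc3ccc(NC(=O)C4(C(=O)Nc5ccc(F)cc5)CC4)cc3)nc2n1C1CCCC1`, is the next compound. It differs from compound 3 in one place: 4-fluorophenyl in place of 3-fluorophenyl on an amide-type nitrogen.

For the measured compounds named here, three measured steps bear on this change, since each alters the same aryl group on the amide-type nitrogen: a number 2.8 percentage points higher from compound 1 to compound 2 (within the scatter), a number 2.6 percentage points higher from compound 1 to compound 3 (within the scatter) and a number 0.2 percentage points lower from compound 2 to compound 3 (within the scatter). Every one of them lies within the scatter, although none of them moves a group from one position of the ring to another while keeping the group itself. With so little movement across all three variations of that aryl group, no step beyond the scatter is expected in this assay for compound 4 in either direction.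

Compound 4 is therefore estimated at 90%, with a range from 80% to 96%, an expected step of a number 1.8 percentage points lower from compound 3 to compound 4 (within the scatter).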

Compound 4, percent growth inhibition at one concentration: 102%
Beside the measured number, compound 4's estimate is 12 percentage points below it, outside the stated range (above it).
By their numbers in this assay, from the lowest: compounds 1, 3, 2 and 4 (each within the scatter of the next, the first and the last beyond it).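

In this assay, for the compounds shown here, the exchange of 3-fluorophenyl for 4-fluorophenyl on the amide-type nitrogen gives a number 10.2 percentage points higher from compound 3 to compound 4 (beyond the scatter) and is the first step at this place to pass beyond the scatter, although the two groups hold the same atoms, joined differently. Compound 4 also separates from the trifluoromethyl-bearing compound, with a number 12.8 percentage points higher from compound 1 to compound 4 (beyond the scatter) as the step, whereas a number 10 percentage points higher from compound 2 to compound 4 (within the scatter) leaves it unresolved from the methoxycarbonyl-bearing compound, so the earlier picture of a place that tolerates every variation holds only in part. No measurement at hand explains why the two fluorophenyl groups part in this way.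

The compounds shown leave open whether the gain belongs to fluoro in particular or would persist with a chloro, methoxy or amino group in place of the fluoro of 4-fluorophenyl. They also leave open whether the separation of compound 4 from compound 3 would hold at other concentrations, since every reading here comes from a single tested concentration and all of them lie close together near the top of the scale.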